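Trifluoromethyl chromene series: amide substituent change on compound 1

The source may report more compounds than this note shows. Statements on the series, on what has been measured and on what is new or still open speak of the compounds shown alone.

Measured compounds in a functional assay on HeLa cells (Homo sapiens) for inhibition, read by MTT assay, with a stated time of 24 h; on this read-out lower numbers stand for stronger inhibition and higher numbers for weaker inhibition:
- compound 1 `CCOC(=O)C1=Cc2ccccc2OC1(OCc1cn(CC(=O)NC2CCCCC2)nn1)C(F)(F)F`: compound 1 gives 11400 nM
- compound 2 `Cc1ccc(-c2cc(COC3(C(F)(F)F)Oc4ccccc4C=C3C(=O)O)on2)cc1`: compound 2 gives 33400 nM
- compound 3 `CCOC(=O)C1=Cc2ccccc2OC1(OCc1cc(-c2ccc(OC)cc2)no1)C(F)(F)F`: compound 3 gives > 150000 nM, a limit of the assay and not a number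

Compound 1 stands lowest of the two numbers shown in this assay; the nearest is compound 2, whose number is higher by a step beyond the usual scatter. For compound 3 only a limit is reported, and one of the three values sits at the limit of > 150000 nM in this assay, at which 1 of the 3 values shown sits.

Compound 4 `CCOC(=O)C1=Cc2ccccc2OC1(OCc1cn(CC(=O)Nc2ccccc2F)nn1)C(F)(F)F` is not yet measured. It differs from compound 1 in one place: 2-fluorophenyl in place of cyclohexyl on an amide-type nitrogen. Among the measured compounds shown here, no measured pair shows this change, so no step size is known for it. Given only the value of compound 1, 11400 nM, the expected step of a 1.0-fold lower number from compound 1 to compound 4 (0.02 log units; within the scatter) is taken as none beyond the scatter, with a wide range to allow for either direction. Compound 4 is therefore estimated at 11000 nM in this assay, between 3500 nM and 35000 nM.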

Compound 4, half-maximal inhibitory concentration: 49900 nM
The estimate for compound 4 lay 4.5-fold (0.66 log units) below the measured number; the whole stated range lies below it.
By their numbers in this assay, from the lowest: compound 1; then compounds 2 and 4 (each within the scatter of the next). At a limit, above all of these: compound 3.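

Among the compounds shown here, the amide-type nitrogen is the first place where a single change can be read: in this assay, 2-fluorophenyl in place of cyclohexyl gives a 4.4-fold higher number from compound 1 to compound 4 (0.64 log units; beyond the scatter). The substituent on this nitrogen therefore affects the read-out, and of these two groups, cyclohexyl goes with the stronger inhibition. Nothing in the available data bears on what lies behind this step.

This single pair does not separate the change from a non-aromatic to an aromatic ring from the addition of fluorine, and an unsubstituted phenyl on the same nitrogen would part the two. Also open, from the compounds shown here alone, is how the read-out responds to a methyl group, a longer alkyl chain or a chain ending in a dimethylamino group on this nitrogen.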